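Swapping the Benzyl Group in a Pyrazole Carboxamide Series

The compounds below may be only part of what the source reports. "The series", "measured", "known", "first", "only" and "open" are said of these compounds alone.

Of the compounds shown here, three have been tested in a functional assay on MCF7 cells (Homo sapiens) for antiproliferative activity, read by MTT assay, with a stated time of 48 h, in the presence of a further agent that is not named here; on this read-out higher numbers stand for weaker inhibition of growth and lower numbers for stronger inhibition of growth. Compound 1 `O=C(NOCc1ccc(Cl)cc1Cl)c1cn(-c2ccccc2)nc1-c1ccccc1` gives 9660 nM. Among the compounds with values here, compound 2 `COc1ccc(-c2nn(-c3ccccc3)cc2C(=O)NOCc2ccc(Cl)cc2Cl)cc1` gives 2570 nM, and the only single-change step measured so far, a 3.8-fold lower number from compound 1 to compound 2 (0.58 log units; beyond the scatter), concerns a methoxy group on an aromatic carbon. Compound 3 `O=C(NOCc1ccccc1F)c1cn(-c2ccccc2)nc1-c1ccc(F)cc1` gives 12000 nM, the highest of the three numbers; it stands close to compound 1, within the scatter, and beyond the scatter from compound 2.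

Compound 4 `O=C(NOCc1ccc(Cl)cc1Cl)c1cn(-c2ccccc2)nc1-c1ccc(F)cc1` has not yet been measured. It differs from compound 3 by 2,4-dichlorophenyl in place of 2-fluorophenyl on a saturated chain carbon bound to an oxygen. Within the data shown here, no measured step touches this part of the molecule, so the one step that exists gives no guidance here. The nearest comparison is compound 1, which carries the same 2,4-dichlorobenzyl group but differs from compound 3 in a second place as well, and whose number sits within the scatter of compound 3.

On that basis, the expected step of a 1.3-fold lower number from compound 3 to compound 4 (0.10 log units; within the scatter) is one that stays within the scatter. Compound 4 is therefore estimated at 9500 nM, within a range of 3500 nM to 25000 nM.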

Compound 4, concentration for 50% growth inhibition: 25300 nM
Compound 4: the middle estimate sits 2.7-fold (0.43 log units) below what was measured, and the stated range ends below it.
By their numbers in this assay, from the lowest: compound 2; then compounds 1 and 3 (each within the scatter of the next); then compound 4.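

In this assay, the first step measured at this position, a 2.1-fold higher number from compound 3 to compound 4 (0.32 log units; beyond the scatter), shows that 2,4-dichlorophenyl in place of 2-fluorophenyl on a saturated chain carbon bound to an oxygen weakens growth inhibition slightly rather than leaving it unchanged. With the 2,4-dichlorobenzyl group held fixed, the aromatic carbon that carries hydrogen, methoxy or fluoro also matters: fluoro in place of hydrogen gives a 2.6-fold higher number from compound 1 to compound 4 (0.42 log units; beyond the scatter), and fluoro in place of methoxy gives a 9.8-fold higher number from compound 2 to compound 4 (0.99 log units; beyond the scatter). Nothing measured here explains either change.

Going by these compounds, this swap has been read only in compounds carrying fluoro at that aromatic carbon, so its effect alongside hydrogen or methoxy remains open. Also open, on these data alone, is how an amine or a carboxylic acid on the benzyl group, or a longer chain in its place, would behave.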